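Chloro added to the pyrazole phenyl of compound 3

The source may hold more compounds than are shown below. What is called first, only, known or untested is meant among the compounds shown, and "the series" means these compounds.

Compound 1 `NS(=O)(=O)c1ccc(N2N=C(c3ccc(Cl)cc3Cl)CC2c2cn(-c3ccccc3)nc2-c2ccccc2)cc1` in an ADME assay on Vero cells (Chlorocebus sabaeus) for cytotoxicity, read by MTT assay, with a stated time of 72 h (on this read-out lower numbers stand for higher toxicity in this test and higher numbers for lower toxicity in this test), gives > 437000 nM, which is a limit of the assay and not a number.
Compound 2 `NS(=O)(=O)c1ccc(N2N=C(c3ccc(F)cc3)CC2c2cn(-c3ccccc3)nc2-c2ccccc2)cc1` in this assay gives > 807000 nM, again a limit rather than a number.
Compound 3 `COc1ccc(C2=NN(c3ccc(S(N)(=O)=O)cc3)C(c3cn(-c4ccccc4)nc3-c3ccccc3)C2)cc1` in this assay gives 40200 nM.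

Compound 3 is thus the only one of the three to return an actual number in this assay; the other two sit at limits, as the limit of > 437000 nM in this assay, at which 1 of the 3 values shown sits, and the limit of > 807000 nM in this assay, at which 1 of the 3 values shown sits, record. The steps to it are large: an at least 10-fold lower number from compound 1 to compound 3 (1.03 log units; beyond the scatter) and an at least 20-fold lower number from compound 2 to compound 3 (1.30 log units; beyond the scatter), whereas a step that the two limits leave unreadable from compound 1 to compound 2 cannot be sized from two limits.

Compound 4 `COc1ccc(C2=NN(c3ccc(S(N)(=O)=O)cc3)C(c3cn(-c4ccccc4)nc3-c3ccc(Cl)cc3)C2)cc1` differs from compound 3 by chloro in place of hydrogen on an aromatic carbon. Every measured step concerns the aryl group on the carbon with a double bond to nitrogen, so none of them touches the position changed here, and no direct guide to the size of this step exists among the three compounds. With nothing to point either way, the expectation for this assay is a step of no more than the scatter, in no particular direction, a 1.1-fold lower number from compound 3 to compound 4 (0.06 log units; within the scatter).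

Compound 4 is therefore estimated at 35000 nM, with a range from 12000 nM to 110000 nM.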

Compound 4, half-maximal cytotoxic concentration: 31300 nM
For compound 4 the middle estimate is 1.1-fold (0.05 log units) above the measured one, and the stated range covers the measured number.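

In this assay the change from phenyl to 4-chlorophenyl, the only change shown away from the aryl group on the carbon with a double bond to nitrogen, gives a 1.3-fold lower number from compound 3 to compound 4 (0.11 log units; within the scatter) and so stays small, whereas swapping that aryl group gave large steps to compound 3. Adding this one chlorine therefore leaves the read-out where it was, and compound 4 joins compound 3 in returning an actual number rather than a limit of the assay. Nothing measured among these compounds bears on why this step stays so small.

From the compounds shown here alone, whether this position would read the same with a group other than chloro, such as an amine, a carboxylic acid or a longer chain, remains open, as does whether chloro elsewhere on this phenyl would behave alike. Also open, going by these compounds, is whether the same phenyl to 4-chlorophenyl change would stay as small when paired with the 4-fluorophenyl or 2,4-dichlorophenyl group of compound 2 or compound 1, the two compounds that sit at limits.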